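One Chlorine Instead of Two: Expecting Another Limit

The source may hold more compounds than are shown below. What is called first, only, known or untested is meant among the compounds shown, and "the series" means these compounds.

Of the compounds shown here, two have been measured so far in a functional assay on the whole organism (strain Wistar) with Rattus norvegicus as the target, with a stated time of 5 min (a lower number here means that less compound is needed, a higher number that more compound is needed for the effect), and both stop at the upper boundary of the test. Compound 1, `CCC1(CCCCN2CCN(c3ccc(Cl)c(Cl)c3)CC2)C(=O)Nc2ccccc21`, gives a reading of > 20 mg/kg in this assay, which is a limit of the test and not a measured number. Compound 2, `CCC1(CCCCN2CCN(c3ccccc3OC)CC2)C(=O)N(Cc2ccccc2)c2ccccc21`, gives > 20 mg/kg in this assay, again only a limit. Compound 1 therefore stands at the limit of > 20 mg/kg in this assay, at which 2 of the 2 values shown sit, with no finite value among the compounds to place it above or below.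

Compound 3, `CCC1(CCCCN2CCN(c3ccccc3Cl)CC2)C(=O)Nc2ccccc21`, is the next compound to be measured in this assay. It differs from compound 1 by 2-chlorophenyl in place of 3,4-dichlorophenyl on an amine nitrogen in a ring. Within the data shown here, no step between two measured compounds is available to show what this kind of change does here, since both values so far are limits. The step from compound 1 to compound 3 is therefore expected to be a number no higher from compound 1 to compound 3 (the limit leaves the size open), a change that would stay within the usual scatter, with a good chance that the test again reports only a limit. For compound 3 in this assay the estimate is 20 mg/kg, in a range from 8 mg/kg to 40 mg/kg.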

Compound 3, minimum effective dose: > 20 mg/kg
Compound 3: no number, only a limit; the forecaster's own chance of this, stated with the estimate: 70%; the middle value sits exactly at the limit.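

In this assay compound 3 gives > 20 mg/kg, which is a limit and not a number. Compound 1 also gives only a limit, so no step between compound 1 and compound 3 can be read: the limit of > 20 mg/kg in this assay, at which 3 of the 3 values shown sit.

The compounds shown leave open whether 2-chlorophenyl in place of 3,4-dichlorophenyl changes the minimum effective dose at all.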